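The compounds below may be only part of what the source reports. "The series", "measured", "known", "first", "only" and "open" are said of these compounds alone.

Compound 1 `CC(Oc1ccc(-c2ccccc2)cc1)C(=O)Cn1nnc(-c2ccc(Cl)cc2)n1` gives 25 nM in an assay on microsomes from brain for inhibition of Fatty-acid amide hydrolase 1 (Rattus norvegicus), read by fluorescence and HPLC, with a stated time of 60 min; on this read-out lower numbers stand for stronger inhibition and higher numbers for weaker inhibition. Within the data shown here, compound 2 `COC(=O)c1ccc(-c2nnn(CC(=O)C(C)Oc3ccc(-c4ccccc4)cc3)n2)cc1` gives 23 nM in this assay; the only single-point step measured so far, a 1.1-fold lower number from compound 1 to compound 2 (0.04 log units; within the scatter), lies on the aryl attached to the shared core, not on the ether side. Compound 3 `CC(Oc1ccc(Oc2ccc(F)cc2)cc1)C(=O)Cn1nnc(-c2ccc(C(=O)O)cc2)n1` gives 100 nM in this assay, the highest of the three numbers, beyond the scatter from both compound 1 and compound 2.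

Compound 4 `CC(Oc1ccc(-c2ccccc2)cc1)C(=O)Cn1nnc(-c2ccc(C(=O)O)cc2)n1` is not yet measured. It differs from compound 3 in one place: phenyl in place of 4-fluorophenoxy on an aromatic carbon. Among the measured compounds shown here, no measured step touches this position. Compound 3 differs from compound 2 in two places, this exchange and the ester-to-acid change, and the two together span the gap between compound 2 at 23 nM and compound 3 at 100 nM; how much of that gap belongs to each change is not known. Compound 4 is therefore expected to give a lower number than compound 3, by a step of a 2.2-fold lower number from compound 3 to compound 4 (0.35 log units; beyond the scatter), estimated at 45 nM with a range of 18 nM to 120 nM.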

Compound 4, half-maximal inhibitory concentration: 83 nM
Compound 4: the middle estimate sits 1.8-fold (0.27 log units) below what was measured; measured number inside the range.
By their numbers in this assay, from the lowest: compounds 2 and 1 (each within the scatter of the next); then compounds 4 and 3 (each within the scatter of the next).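

In this assay, the exchange at this position gives a 1.2-fold lower number from compound 3 to compound 4 (0.08 log units; within the scatter), so with carboxy on the aryl of the shared core, phenyl and 4-fluorophenoxy are not told apart. The change from ester to acid, with phenyl held constant, gives a 3.6-fold higher number from compound 2 to compound 4 (0.56 log units; beyond the scatter) and is beyond the scatter, as is the exchange of chloro for carboxy, which gives a 3.3-fold higher number from compound 1 to compound 4 (0.52 log units; beyond the scatter); by contrast, the earlier exchange of chloro for methoxycarbonyl, a 1.1-fold lower number from compound 1 to compound 2 (0.04 log units; within the scatter), stayed within it. No measurement at hand explains these steps.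

On these data alone, whether phenyl and 4-fluorophenoxy also stay within the scatter of each other when the aryl carries chloro or methoxycarbonyl remains open. So does the result of a primary amide or a nitrile in place of carboxy.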